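A few compounds are considered here, and "the series" means these few. Any claim that something is new, unique, unknown or untested is made for them only; others in the source may bear on it.

Compound 1 `C=CC1=C(C(=O)Nc2ccccc2)C(c2ccc(Cl)c(Cl)c2)OC1` in a functional assay on SW480 cells (Homo sapiens) for cytotoxicity, read by MTT assay, with a stated time of 24 h (on this read-out higher numbers stand for weaker inhibition and lower numbers for stronger inhibition), gives > 100000 nM, a limit of the assay.
Compound 2 `C=CC1=C(C(=O)Nc2ccccc2)C(c2ccc(OC)cc2)OC1` in this assay gives > 100000 nM, again only a limit.
Compound 3 `C=CC1=C(C(=O)Nc2ccccc2)C(c2ccc(F)cc2)OC1` in this assay gives > 100000 nM, also a limit.

Compound 2 therefore stands where every measured compound stands: at the limit of > 100000 nM in this assay, at which 3 of the 3 values shown sit. The measured steps, a step that the two limits leave unreadable from compound 1 to compound 2, a step that the two limits leave unreadable from compound 1 to compound 3 and a step that the two limits leave unreadable from compound 2 to compound 3, each run between two limits and give no readable size. The step to compound 4 `C=CC1=C(C(=O)NCCC)C(c2ccc(OC)cc2)OC1` is propyl in place of phenyl on an amide-type nitrogen. For the measured compounds named here, no measured step bears on this change, and none shows any movement away from the limit, so in this assay no step beyond the scatter is expected, and the step from compound 2 to compound 4 is estimated as a number no higher from compound 2 to compound 4 (the limit leaves the size open). Compound 4 is expected to give about 100000 nM, within 30000 nM to 300000 nM, most likely again reported only as a limit.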

Compound 4, half-maximal inhibitory concentration: > 100000 nM
Compound 4 gave a limit, no number (the forecaster's own chance of this, stated with the estimate: 80%); the middle value sits exactly at the limit.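

Compound 2 and compound 4 both sit at a limit, so no size can be read for the change from phenyl to propyl: the limit of > 100000 nM in this assay, at which 4 of the 4 values shown sit.

The compounds shown leave open how strongly any of them acts in this assay, and whether either group matters.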